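Notes on a nitrooxy step in a paw edema series

The source may hold more compounds than are shown below. What is called first, only, known or untested is meant among the compounds shown, and "the series" means these compounds.

Measured so far:
compound 1, `Cc1ccc(S(=O)(=O)Nn2c(C)nc3ccccc3c2=O)cc1`, 3.2%
compound 2, `Cc1nc2ccccc2c(=O)n1NC(=O)NC(C)(C)C`, 10.4%
compound 3, `Cc1ccc(S(=O)(=O)Nn2c(CO[N+](=O)[O-])nc3ccccc3c2=O)cc1`, 6.4%

All three were tested in a functional assay on the whole organism (strain Sprague-Dawley) for inhibition, with Rattus norvegicus as the target, read by paw edema, with stated times of 30 min and 1 h, at a dose of 80 mg/kg by the oral route; on this read-out higher numbers stand for more inhibition at the one dose given (going by the name of the read-out) and lower numbers for less inhibition. Compound 1 gives 3.2% in this assay, compound 3 gives 6.4% and compound 2 gives 10.4%. The three numbers sit close together, and none of the gaps between them is larger than the usual scatter, so no order can be read from them.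

Compound 1 and compound 3 share a core and differ in one place, (nitrooxy in place of hydrogen on a saturated chain carbon bound to an aromatic carbon). The step this change made, a number 3.2 percentage points higher from compound 1 to compound 3 (within the scatter), is within the scatter and counts as no measurable effect. Compound 2 carries a different core; the difference between the two cores is not broken down here.

Compound 4, `CC(C)(C)NC(=O)Nn1c(CO[N+](=O)[O-])nc2ccccc2c1=O`, has not yet been measured in this assay. It stands to compound 2 as compound 3 stands to compound 1: nitrooxy in place of hydrogen on a saturated chain carbon bound to an aromatic carbon. The same kind of change has been seen once, in the pair compound 1 to compound 3, where it stayed within the scatter. On that basis the step from compound 2 to compound 4 is expected to be small as well, about a number 2.6 percentage points higher from compound 2 to compound 4 (within the scatter), because a number 3.2 percentage points higher from compound 1 to compound 3 (within the scatter) gave no real movement. Compound 4 is therefore expected to give roughly 13% in this assay, with a plausible range from 3% to 23%. The expectation rests on a single prior instance of the change and on the value of compound 2, so it carries wide uncertainty.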

Compound 4, a percentage reported as inhibition, in the whole organism at one dose (the size of the read-out at that dose, not a potency): 6.4%
For compound 4 the middle estimate is 6.6 percentage points above the measured one; low and high end bracket the measured number.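

On the core of compound 2, methyl to (nitrooxy)methyl in this assay gives a number 4 percentage points lower from compound 2 to compound 4 (within the scatter) and thus no measurable effect, and the two instances of this change do not differ: the same change on two cores in this assay, a number 3.2 percentage points higher (within the scatter) from compound 1 to compound 3 and a number 4 percentage points lower (within the scatter) from compound 2 to compound 4, 7.2 percentage points apart, within the scatter of two such steps.

Within this small set, the change therefore reads the same on both cores, with no measurable effect in either pair and no sign that the core alters the outcome. This does not show that nitrooxy is without any effect, or that the change would behave alike on every core in the series. It rests on two pairs at one dose and on one read-out, all with little inhibition, so a small real effect would not be distinguishable from the scatter and no direction can be assigned to the change.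

The compounds shown carry only hydrogen or nitrooxy in this place, on a saturated chain carbon bound to an aromatic carbon, so it remains open whether an amine, a carboxylic acid or a longer chain there would move the read-out beyond the scatter. It also remains open whether nitrooxy would have a measurable effect on a core that gives much stronger inhibition in this assay than the compounds shown.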